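The compounds below may be only part of what the source reports. "The series", "measured", "known", "first", "only" and "open" are said of these compounds alone.

In a functional assay on HeLa cells (Homo sapiens) for antiproliferative activity, read by MTT assay, with a stated time of 72 h (on this read-out lower numbers stand for stronger inhibition and higher numbers for weaker inhibition), compound 1 `Nc1nc(N)c2cc(CSC(=S)N3CCN(c4ccccc4)CC3)ccc2n1` gives 2840 nM, compound 2 `COc1ccc(N2CCN(C(=S)SCc3ccc4nc(N)nc(N)c4c3)CC2)cc1` gives 1660 nM and compound 3 `Nc1nc(N)c2cc(CSC(=S)N3CCN(c4ccccc4F)CC3)ccc2n1` gives 6660 nM, the highest of the three numbers and so the weakest inhibition. Compound 4 `Nc1nc(N)c2cc(CSC(=S)N3CCN(c4ncccn4)CC3)ccc2n1` carries pyrimidin-2-yl in place of 2-fluorophenyl on an amine nitrogen in a ring. Among the measured steps, methoxy in place of hydrogen gave a 1.7-fold lower number from compound 1 to compound 2 (0.23 log units; within the scatter), and swapping the whole group gave a 4.0-fold higher number from compound 2 to compound 3 (0.60 log units; beyond the scatter). Within the data shown here, no measured compound carries pyrimidin-2-yl, so, guided by the fluoro step of a 2.3-fold higher number from compound 1 to compound 3 (0.37 log units; beyond the scatter), only a small move towards a lower number is expected in this assay, perhaps within the scatter. The expected step is a 1.9-fold lower number from compound 3 to compound 4 (0.28 log units; within the scatter). Compound 4 is estimated at 3500 nM, with a range of 1300 nM to 9000 nM.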

Compound 4, half-maximal inhibitory concentration: 4360 nM
Compound 4: the middle estimate sits 1.2-fold (0.10 log units) below what was measured, within the range that was stated.
By their numbers in this assay, from the lowest: compounds 2, 1, 4 and 3 (each within the scatter of the next, the first and the last beyond it).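

At this ring nitrogen, an aromatic ring with 2 hetero atoms does about as well as the carbon-only rings: pyrimidin-2-yl gives a 1.5-fold lower number from compound 3 to compound 4 (0.18 log units; within the scatter) and a 1.5-fold higher number from compound 1 to compound 4 (0.19 log units; within the scatter) without separating from either. Among these compounds, only the 4-methoxyphenyl group stands apart, with a 2.6-fold higher number from compound 2 to compound 4 (0.42 log units; beyond the scatter) as the one step here beyond the scatter, so the 2 hydrogen-bond acceptors that enter bring no gain over compound 2. No measurement at hand explains these differences.

From the compounds shown here alone, whether a small methyl or a non-aromatic cyclohexyl on this nitrogen would hold the same level remains open. So does the effect of a pyridin-2-yl ring, with a single ring nitrogen.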